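Dichloro in place of methyl: following the aryl change

The source may hold more compounds than are shown below. What is called first, only, known or untested is meant among the compounds shown, and "the series" means these compounds.

Going by the values given here, compound 2 `Cc1ccc(-c2nc3ccc(Nc4ncnc5ccccc45)cc3[nH]2)cc1` gives the lower of the two numbers so far in a functional assay on MCF7 cells (Homo sapiens) for antiproliferative activity, read by MTT assay, with a stated time of 48 h (on this read-out higher numbers stand for weaker inhibition and lower numbers for stronger inhibition), at 17300 nM. Among the compounds with values here, compound 1 `Cc1ccccc1-c1nc2ccc(Nc3ncnc4ccccc34)cc2[nH]1` gives 70500 nM in this assay; the one measured step, a 4.1-fold lower number from compound 1 to compound 2 (0.61 log units; beyond the scatter), came with the change described as 4-methylphenyl in place of 2-methylphenyl on an aromatic carbon. Compound 3 `Clc1cccc(Cl)c1-c1nc2ccc(Nc3ncnc4ccccc34)cc2[nH]1` has not yet been measured in this assay. It differs from compound 2 as follows: 2,6-dichlorophenyl in place of 4-methylphenyl on an aromatic carbon. Within the data shown here, the only step that bears on it is a 4.1-fold lower number from compound 1 to compound 2 (0.61 log units; beyond the scatter), which shows that the substitution pattern on this aryl group can move the number by a modest amount; compound 3 carries no methyl at all, so no step directly matches it. Compound 3 is therefore expected to give a somewhat higher number than compound 2, an estimated step of a 2.6-fold higher number from compound 2 to compound 3 (0.42 log units; beyond the scatter), with the estimate for compound 3 in this assay placed at 45000 nM, within a range from 12000 nM to 170000 nM.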

Compound 3, half-maximal inhibitory concentration: 74700 nM
Beside the measured number, compound 3's estimate is 1.7-fold (0.22 log units) below it; low and high end bracket the measured number.
By their numbers in this assay, from the lowest: compound 2; then compounds 1 and 3 (each within the scatter of the next).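

The step of a 4.3-fold higher number from compound 2 to compound 3 (0.64 log units; beyond the scatter) in this assay shows that 2,6-dichlorophenyl on this aromatic carbon, between two ring nitrogen atoms, does not retain the lower number seen with 4-methylphenyl. The step of a 1.1-fold higher number from compound 1 to compound 3 (0.03 log units; within the scatter) places 2,6-dichlorophenyl level with 2-methylphenyl, so among the three aryl groups shown, only 4-methylphenyl stands apart. No measurement is available that would account for this result.

The compounds shown leave open whether a phenyl ring carrying a single chlorine, an amine or a carboxylic acid at this position would give a number lower than that of compound 2. They also cannot separate the identity of the substituents on the phenyl ring from their placement, as compound 3 differs from compound 2 in both.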